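This account rests on a few compounds, and the source may have more. Where it says the series, first, only, none or still open, it means among the compounds named here.

Measured so far:
- compound 1 `Cc1ccc(Sc2ccc(N(C[C@H](O)C(=O)NO)S(C)(=O)=O)cc2)cc1`, in an assay on isolated protein for inhibition of matrix metalloproteinase-9 (Homo sapiens) (a lower number here means a stronger inhibitor, a higher number a weaker inhibitor), compound 1 gives 54 nM
- compound 2 `CC(C)C(=O)N(C[C@H](O)C(=O)NO)c1ccc(Oc2ccc(Cl)cc2)cc1`, in this assay compound 2 gives 242 nM

Of these two numbers, compound 1 has the lower one, and the gap to compound 2 is beyond the usual scatter. Compound 3 `Cc1ccc(C#Cc2ccc(N(C[C@H](O)C(=O)NO)S(C)(=O)=O)cc2)cc1` keeps the shared core of compound 1 and changes one place: 2-(4-methylphenyl)ethynyl in place of (4-methylphenyl)sulfanyl on an aromatic carbon. Within the data shown here, no measured pair shows this kind of change. The step from compound 1 to compound 3 is expected to be small, likely within the scatter, with a slight lean toward a weaker inhibitor, as a 1.6-fold higher number from compound 1 to compound 3 (0.20 log units; within the scatter). Compound 3 is therefore estimated at 85 nM, in a range from 20 nM to 350 nM.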

Compound 3, half-maximal inhibitory concentration: 44 nM
Compound 3: middle estimate off by 1.9-fold (0.29 log units), on the high side, within the range that was stated.
By their numbers in this assay, from the lowest: compounds 3 and 1 (each within the scatter of the next); then compound 2.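

Putting 2-(4-methylphenyl)ethynyl in place of (4-methylphenyl)sulfanyl gives a 1.2-fold lower number from compound 1 to compound 3 (0.09 log units; within the scatter) in this assay. At this position, then, the sulfur atom is not required to keep the number at this level: an all-carbon link with a triple bond, carrying the same 4-methylphenyl ring, does as well. No available evidence explains why the two groups match. Still open, as far as these compounds go, is whether an amide link or a longer saturated carbon chain at this position would give a similar number, and what replacing the methyl with methoxy would do.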